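The source may report more compounds than this note shows. Statements on the series, on what has been measured and on what is new or still open speak of the compounds shown alone.

In a functional assay on MCF7 cells (Homo sapiens) for cytotoxicity, read by MTT assay, with a stated time of 72 h (on this read-out lower numbers stand for stronger inhibition and higher numbers for weaker inhibition), compound 1 `COc1ncc(-c2ccc3nc(NC(=O)N4CCCC4)nn3c2)cc1NS(=O)(=O)c1ccc(F)cc1` gives 1660 nM and compound 2 `COc1ncc(-c2ccc3nc(NC(=O)NCC(=O)N4CCCC4)nn3c2)cc1NS(=O)(=O)c1ccc(F)cc1` gives 2130 nM against compound 3 `COc1ncc(-c2ccc3nc(NC(=O)NCCN(C)C)nn3c2)cc1NS(=O)(=O)c1ccc(F)cc1` at 560 nM, the lowest of the three numbers. Compound 4 `COc1ncc(-c2ccc3nc(NC(=O)NCC(=O)N4CCOCC4)nn3c2)cc1NS(=O)(=O)c1ccc(F)cc1` differs from compound 3 as follows: (morpholin-4-yl)carbonyl in place of (dimethylamino)methyl on a saturated chain carbon bound to an amide-type nitrogen. In words, (morpholin-4-yl)carbonyl stands in place of (dimethylamino)methyl on a saturated chain carbon bound to an amide-type nitrogen. The nearest measured step is a 3.8-fold lower number from compound 2 to compound 3 (0.58 log units; beyond the scatter), which runs the opposite way with (pyrrolidin-1-yl)carbonyl leaving. Also relevant are a 3.0-fold lower number from compound 1 to compound 3 (0.47 log units; beyond the scatter) and a 1.3-fold higher number from compound 1 to compound 2 (0.11 log units; within the scatter). A modest rise of similar size is therefore expected in this assay, the estimated step being a 4.1-fold higher number from compound 3 to compound 4 (0.61 log units; beyond the scatter). The estimate for compound 4 is 2300 nM, with an expected range from 900 nM to 5500 nM.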

Compound 4, half-maximal inhibitory concentration: 630 nM
Estimate against measurement, compound 4: 3.7-fold (0.56 log units) above; the measured number lies below the stated range.
By their numbers in this assay, from the lowest: compounds 3 and 4 (each within the scatter of the next); then compounds 1 and 2 (each within the scatter of the next).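

In this assay, morpholin-4-yl in place of pyrrolidin-1-yl on a carbonyl carbon gives a 3.4-fold lower number from compound 2 to compound 4 (0.53 log units; beyond the scatter), so the ring on that carbonyl matters at this position. (Morpholin-4-yl)carbonyl in place of (dimethylamino)methyl gives a 1.1-fold higher number from compound 3 to compound 4 (0.05 log units; within the scatter), so a dimethylamino chain end is not needed to reach this level. The full (((morpholin-4-yl)carbonyl)methyl)amino group in place of pyrrolidin-1-yl gives a 2.6-fold lower number from compound 1 to compound 4 (0.42 log units; beyond the scatter). Nothing available explains these steps. Still open, from the compounds shown here alone, is how a piperazine or a carboxylic acid at the chain end, or a longer chain, would compare with compound 4.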